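Compound 1 with a new hydroxy-methoxy ring group

The compounds below may be only part of what the source reports. "The series", "measured", "known", "first", "only" and "open" are said of these compounds alone.

Compound 1 (`Cc1cc(C)cc(/C=C(/SCc2ccc(F)cc2)C(=O)c2ccc(Br)cc2)c1`) gives 10000 nM
Compound 2 (`Cc1ccc(S/C(=C/c2cc([N+](=O)[O-])ccc2F)C(=O)c2ccc(Cl)cc2)cc1`) gives 10000 nM

In a functional assay on DU-145 cells (Homo sapiens) for inhibition, read by trypan blue exclusion, with a stated time of 96 h (on this read-out higher numbers stand for weaker inhibition of growth and lower numbers for stronger inhibition of growth), compound 1 stands level with compound 2 at the digits shown, so neither can be ranked over the other. For the measured compounds named here, the two also differ in more than one place, so no measured step is available to guide a prediction.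

Compound 3 (`COc1ccc(/C=C(/SCc2ccc(F)cc2)C(=O)c2ccc(Br)cc2)cc1O`) keeps the core of compound 1 and changes one group: 3-hydroxy-4-methoxyphenyl in place of 3,5-dimethylphenyl on a double-bonded chain carbon bound to a double-bonded chain carbon. The counts show that the incoming group carries a hydrogen-bond donor and hydrogen-bond acceptors, which the outgoing group lacks.

With compound 1 at 10000 nM, a high number on this scale, there is room for a fall. This is a judgement, not a trend drawn from data. A sizeable move towards stronger inhibition is expected, and the expected step is a 13-fold lower number from compound 1 to compound 3 (1.10 log units; beyond the scatter) in this assay, although no change beyond the scatter remains possible. For compound 3, 800 nM is the estimated value, with 30 nM to 10000 nM as the expected range.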

Compound 3, concentration for 50% growth inhibition: 1000 nM
Beside the measured number, compound 3's estimate is 1.3-fold (0.10 log units) below it; the measured number falls inside the stated range.
By their numbers in this assay, from the lowest: compound 3; then compounds 1 and 2 (each within the scatter of the next).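

In this assay, placing 3-hydroxy-4-methoxyphenyl in place of 3,5-dimethylphenyl on a double-bonded chain carbon bound to a double-bonded chain carbon gives a 10-fold lower number from compound 1 to compound 3 (1.00 log units; beyond the scatter) and provides the first measured sign that the group at this place can shift growth inhibition. The single six-membered aromatic ring of carbon stays through this change, while the incoming group brings oxygen atoms, a hydrogen-bond donor and hydrogen-bond acceptors that the outgoing group lacks. No independent measurement accounts for the step, so the link between these counted differences and the lower number remains untested.

The hydroxy and methoxy groups enter together, so the compounds shown cannot tell whether one of them alone, as in 3-hydroxyphenyl or 4-methoxyphenyl, would account for the step. On these data alone, it also remains open how an aminophenyl or carboxyphenyl group would behave at this place, and whether the same change would give a similar step with the other parts of the core of compound 1 altered.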